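Swapping the nitrile of compound 2 for a methoxy group

This account rests on a few compounds, and the source may have more. Where it says the series, first, only, none or still open, it means among the compounds named here.

Compound 2 `N#Cc1ccc(COc2c(-c3ccccc3)oc3cc(O)cc(O)c3c2=O)cc1` carries a 4-cyanobenzyl group on the shared core. Among the measured compounds shown here, in an ADME assay on Huh-5-2 cells (Homo sapiens) for cytotoxicity, read by WST assay, with a stated time of 3 days (on this read-out higher numbers stand for lower toxicity in this test and lower numbers for higher toxicity in this test), compound 2 gives 48000 nM, the highest of the two numbers measured so far; compound 1 `O=c1c(OCc2ccccc2Br)c(-c2ccccc2)oc2cc(O)cc(O)c12` gives 12000 nM, and a 4.0-fold higher number from compound 1 to compound 2 (0.60 log units; beyond the scatter). Compound 3 `COc1ccc(COc2c(-c3ccccc3)oc3cc(O)cc(O)c3c2=O)cc1` alters the same substituent: methoxy in place of cyano on an aromatic carbon. For the measured compounds named here, no measured step covers this exact change; the single step available exchanged a whole aryl ring and was modest. The new change is therefore expected to bring a 1.2-fold lower number from compound 2 to compound 3 (0.08 log units; within the scatter). For compound 3 in this assay the estimate is 40000 nM, with a range from 15000 nM to 100000 nM.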

Compound 3, half-maximal cytotoxic concentration: 57000 nM
Compound 3: the middle estimate sits 1.4-fold (0.15 log units) below what was measured; the measured number falls inside the stated range.
By their numbers in this assay, from the lowest: compound 1; then compounds 2 and 3 (each within the scatter of the next).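

In this assay, going from 4-cyanobenzyl to 4-methoxybenzyl gives a 1.2-fold higher number from compound 2 to compound 3 (0.07 log units; within the scatter) and so no readable change, which shows that this position takes either group with the number staying where it was. Compound 3 also stands clear of the 2-bromophenyl compound, with a 4.8-fold higher number from compound 1 to compound 3 (0.68 log units; beyond the scatter) as the step, and compound 2 did the same earlier. No measurement available here explains these numbers. Still open, from the compounds shown here alone, is whether an amine or a carboxylic acid on the same aromatic carbon would keep the number in this range.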